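The source may report more compounds than this note shows. Statements on the series, on what has been measured and on what is new or still open speak of the compounds shown alone.

Of the compounds shown here, three have been measured so far in a physicochemical assay for lipophilicity, using potentiometric titration, at pH 3; on this read-out higher numbers stand for higher lipophilicity and lower numbers for lower lipophilicity. Compound 1, `Cc1cccc(-c2noc(O)n2)c1`, gives 0.8 in this assay. Compound 2, `Cc1cccc(Cc2noc(O)n2)c1`, gives 1.39 in this assay. Compound 3, `Cc1cccc(-c2noc(S)n2)c1`, gives 1.44 in this assay. The difference between the core of compound 1 and the core of compound 2 is not broken down here. Compound 3 differs from compound 1 in a single place, (sulfanyl in place of hydroxy on an aromatic carbon), and that change brought a number 0.64 log units higher from compound 1 to compound 3 (beyond the scatter). Compound 2 and compound 3 lie within the scatter of each other in this assay, while compound 2 stands beyond the scatter away from compound 1.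

Compound 4, `Cc1cccc(Cc2noc(S)n2)c1`, has not yet been measured. It differs from compound 2 in one place, (sulfanyl in place of hydroxy on an aromatic carbon). Going by the values given here, this is the same kind of change as the one from compound 1 to compound 3, with one difference in the surroundings: in compound 4 the changed carbon is two ring bonds from the ring atom that bears a group of 8 heavy atoms, whereas in compound 3 that ring atom bears a group of 7 heavy atoms. A step of a number 0.64 log units higher from compound 2 to compound 4 (beyond the scatter) is expected because the same kind of change gave a number 0.64 log units higher from compound 1 to compound 3 (beyond the scatter). Compound 4 is therefore expected to give about 2.03 in this assay, with a likely range from 1.7 to 2.4.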

Compound 4, distribution coefficient: 1.42
Compound 4: the middle estimate sits 0.61 log units above what was measured; measured number below the stated range.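

In this assay, putting sulfanyl in place of hydroxy gave a number 0.64 log units higher from compound 1 to compound 3 (beyond the scatter) on the core of compound 1, yet the same change gave a number 0.03 log units higher from compound 2 to compound 4 (within the scatter) on the core of compound 2. Going by these compounds alone, this shows that, in this series, the size of the step does not carry over as a fixed amount from one core to the other: the same single change can matter on one core and leave no step that stands out from the scatter on the other, so a step seen on one core is a weak guide to the step on the next. Within the data shown here, it does not show what this change would do on any further core, and with only two pairs it cannot single out which feature of the two cores goes with the different outcomes. No other data are at hand that bear on the contrast between the two pairs.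

The compounds shown leave open how an amine or a carboxylic acid in place of the hydroxy would read in this assay on these two cores. They also leave open whether a longer chain in the group carried by the ring would give a sulfanyl step like that of either pair.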